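The source may hold more compounds than are shown below. What is called first, only, known or untested is meant among the compounds shown, and "the series" means these compounds.

Compound 3 `CCn1c(SCC(=O)Nc2ccc(C(C)=O)cc2)nnc1-c1cc(OC)c(OC)c(OC)c1` and compound 1 `CCn1c(SCC(=O)Nc2ccc(/C(C)=N/O)cc2)nnc1-c1cc(OC)c(OC)c(OC)c1` share one core and differ at a single place: a group of 4 heavy atoms (2 carbon, 1 nitrogen, 1 oxygen; no ring) in place of a group of 3 heavy atoms (2 carbon, 1 oxygen; no ring), on an aromatic carbon. In a functional assay on the whole organism (strain albino) for inhibition, with Rattus norvegicus as the target, read by paw edema, with stated times of 30 min and 5 h, at a dose of 0.28 mmol/kg by the oral route (a lower number here means less inhibition, a higher number more inhibition at the dose given (going by the name of the read-out)), compound 3 gives 64%. In this assay compound 1 gives 61%. The step that this change made is a number 3 percentage points lower from compound 3 to compound 1 (within the scatter), so the two values lie within the scatter of each other and no direction can be read from them.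

Compound 2 `C=CCn1c(SCC(=O)Nc2ccc(C(C)=O)cc2)nnc1-c1ccc(OC)c(OC)c1` is built on a different core; the difference between the core of compound 2 and the core of compound 3 is not broken down here. In this assay compound 2 gives 64%, which is level with compound 3 at the digits reported and within the scatter of compound 1 as well. Together compound 2 and compound 3 hold the highest of the three numbers, though all three values sit within the usual scatter of one another, so the numbers are level.

Compound 4 `C=CCn1c(SCC(=O)Nc2ccc(/C(C)=N/O)cc2)nnc1-c1ccc(OC)c(OC)c1` has not yet been measured in this assay. It stands to compound 2 as compound 1 stands to compound 3: a group of 4 heavy atoms (2 carbon, 1 nitrogen, 1 oxygen; no ring) in place of a group of 3 heavy atoms (2 carbon, 1 oxygen; no ring), on an aromatic carbon. The place is the same in both cases, so this is the same change, made on the other core. From compound 2 to compound 4 the step in this assay is expected to be a number 2 percentage points lower from compound 2 to compound 4 (within the scatter), because the same change gave a number 3 percentage points lower from compound 3 to compound 1 (within the scatter). This expectation rests on a single measured step on one core only, and the two cores have not been compared for how they respond to the change. Compound 4 is therefore estimated at 62% in this assay, expected to fall between 50% and 72%.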

Compound 4, a percentage reported as inhibition, in the whole organism at one dose (the size of the read-out at that dose, not a potency): 79%
Compound 4: middle estimate off by 17 percentage points, on the low side; measured number above the stated range.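

On the core of compound 2, replacing the acetyl on the aromatic carbon had a clear effect in this assay, with a number 15 percentage points higher from compound 2 to compound 4 (beyond the scatter). The same change therefore did not carry over in size or direction from one core to the other, as the two steps differ: the same change on two cores in this assay, a number 3 percentage points lower (within the scatter) from compound 3 to compound 1 and a number 15 percentage points higher (beyond the scatter) from compound 2 to compound 4, 18 percentage points apart, beyond the scatter of two such steps. Among these compounds, this shows that, in this series, the step measured on one core was a poor guide to the step on the other, but with only one pair on each core and a single dose, it gives no general rule for other cores and does not show which part of the difference between the two cores goes with the gap.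

The compounds shown leave open whether the larger step belongs to the allyl chain, to the aromatic ring with its methoxy groups, or to both, since the two cores differ in ways that these pairs do not separate. They also leave open how another group in the same place, such as a carboxylic acid or an amine, would compare with the acetyl on each core.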